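Isopropyl to Fluoro: Expecting Little Change

This account rests on a few compounds, and the source may have more. Where it says the series, first, only, none or still open, it means among the compounds named here.

In an ADME assay on the whole organism with Oryza sativa as the target, tested at 0.1 uM (a lower number here means a stronger effect, a higher number a weaker effect of the compound at the concentration tested), compound 1 `CC(C)c1ccccc1NC(=O)N[C@H](C)c1ccccc1` gives 103%. In this assay compound 2 `CC(C)c1ccccc1NC(=O)N[C@@H](C)c1ccccc1` gives 99%; the step between them is a number 4 percentage points lower from compound 1 to compound 2 (within the scatter), and it rests on (the fact that compounds 1 and 2 differ only in the configuration as drawn). In this assay compound 3 `CC(=O)c1ccccc1NC(=O)N[C@H](C)c1ccccc1` gives 96%; the step here is a number 7 percentage points lower from compound 1 to compound 3 (within the scatter). Among these three numbers compound 2 sits second highest, with compound 3 nearest and compound 1 furthest, both within the scatter.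

Compound 4 `C[C@H](NC(=O)Nc1ccccc1F)c1ccccc1` has not yet been measured in this assay. It differs from compound 2 in one place: fluoro in place of isopropyl on an aromatic carbon. The step that bears most on this change is the one in which acetyl replaced isopropyl on an aromatic carbon, a number 7 percentage points lower from compound 1 to compound 3 (within the scatter), which stayed within the scatter; the change of configuration, a number 4 percentage points lower from compound 1 to compound 2 (within the scatter), also stayed within the scatter. No step beyond the scatter is therefore expected in this assay for compound 4. Compound 4 is expected to give about 98%, between 88% and 108%. The expected step from compound 2 to compound 4 is a number 1 percentage points lower from compound 2 to compound 4 (within the scatter).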

Compound 4, a percentage reported as activity, at one concentration (the size of the read-out at that concentration, not a potency): 98%
The estimate for compound 4 equals the measured number at the digits printed; low and high end bracket the measured number.
By their numbers in this assay, from the lowest: compounds 3, 4, 2 and 1 (each within the scatter of the next).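

Replacing isopropyl, with 3 heavy atoms, by fluoro, with 1 heavy atom, on this aromatic carbon ortho to a large group gives a number 1 percentage points lower from compound 2 to compound 4 (within the scatter). The earlier swap at this carbon put in acetyl, while this one shows that in this assay a single fluorine atom also leaves the read-out within the scatter, so a large cut in the size of the group does not produce a step that can be told from noise. Nothing at hand explains why the number holds across this change.

The compounds shown leave open whether an amine, a carboxylic acid or a longer chain at this carbon would give a step beyond the scatter. Within the data shown here, they also leave open whether any change here would show in this assay, since every step so far lies within the scatter.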